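Anilide series: a pyridin-2-yl amide awaits its writhing-test result

This account rests on a few compounds, and the source may have more. Where it says the series, first, only, none or still open, it means among the compounds named here.

Three amides built on the shared core of compound 1 `COc1cc2c(cc1OC)C(CC(=O)Nc1ccccc1)CC2` have been tested in a functional assay on the whole organism (strain Swiss Albino) for inhibition, with Mus musculus as the target, in the writhing test, with a stated time of 1 h, at a dose of 100 mg/kg by the oral route; a higher number here means more inhibition at the dose given (going by the name of the read-out), a lower number less inhibition. Compound 1 gives 42.8%, compound 2 `COc1cc2c(cc1OC)C(CC(=O)Nc1ccc(Br)cc1)CC2` gives 37.5%, and compound 3 `COc1cc2c(cc1OC)C(CC(=O)Nc1ccc(C)cc1)CC2` gives 41.4%. Compound 3 stands second highest of the three numbers; its nearest neighbour is compound 1, and the step of a number 3.9 percentage points higher from compound 2 to compound 3 (within the scatter) separates it from compound 2. Among the compounds with values here, none of the measured steps, a number 5.3 percentage points lower from compound 1 to compound 2 (within the scatter), a number 1.4 percentage points lower from compound 1 to compound 3 (within the scatter) or a number 3.9 percentage points higher from compound 2 to compound 3 (within the scatter), rises beyond the scatter, so the numbers give no ground to order the three compounds.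

Compound 4 `COc1cc2c(cc1OC)C(CC(=O)Nc1ccccn1)CC2` is not yet measured. It differs from compound 3 as follows: pyridin-2-yl in place of 4-methylphenyl on an amide-type nitrogen. The measured steps all concern a substituent on the aromatic ring of the anilide and not an exchange of that ring itself, so they bear only loosely on this change; what they show is a flat surface. Compound 4 is therefore expected to show a number 1.4 percentage points lower from compound 3 to compound 4 (within the scatter), that is, no step beyond the scatter. The value of compound 4 in this assay is estimated at 40%, within a range of 27% to 53%.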

Compound 4, a percentage reported as inhibition, in the whole organism at one dose (the size of the read-out at that dose, not a potency): 48.1%
Beside the measured number, compound 4's estimate is 8.1 percentage points below it; the measured number falls inside the stated range.
By their numbers in this assay, from the lowest: compounds 2, 3, 1 and 4 (each within the scatter of the next, the first and the last beyond it).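

Within the data shown here, exchanging the whole aromatic ring on the amide-type nitrogen for pyridin-2-yl gives the first step that passes the scatter in this assay: starting from the 4-bromophenyl amide, the result is a number 10.6 percentage points higher from compound 2 to compound 4 (beyond the scatter) and the step is modest. Measured against the other two amides, the exchange gives a number 6.7 percentage points higher from compound 3 to compound 4 (within the scatter) and a number 5.3 percentage points higher from compound 1 to compound 4 (within the scatter) and so separates neither pair, which means this position has shown one modest difference and no clear gain over phenyl or 4-methylphenyl. Among these compounds, nothing measured so far accounts for that single step.

As far as these compounds go, whether pyridin-3-yl or pyridin-4-yl on the same nitrogen would read like compound 4 remains open. So does the outcome of placing a methyl or bromo group on the pyridin-2-yl ring itself.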